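The source may hold more compounds than are shown below. What is called first, only, known or untested is meant among the compounds shown, and "the series" means these compounds.

Measured so far:
Compound 1 `COc1ccc(NS(=O)(=O)c2ccc(N3CCNC3=O)cc2)cc1`: in a functional assay on MCF7 cells (Homo sapiens) for antiproliferative activity, read by sulforhodamine B assay, with a stated time of 48 h (a higher number here means a weaker inhibitor, a lower number a stronger inhibitor), compound 1 gives > 1000 nM, which is a limit of the assay rather than a number.
Compound 2 `Cc1cccc(NS(=O)(=O)c2ccc(N3CCNC3=O)cc2)c1`: in this assay compound 2 gives 190 nM.

Compound 2 holds the only finite number shown in this series; the other value is a limit (the limit of > 1000 nM in this assay, at which 1 of the 2 values shown sits). Compound 3 `O=C1NCCN1c1ccc(S(=O)(=O)Nc2ccccc2)cc1` differs from compound 2 by hydrogen in place of methyl on an aromatic carbon. Within the data shown here, the one measured step, an at least 5.2-fold lower number from compound 1 to compound 2 (0.72 log units; beyond the scatter), swaps 3-methylphenyl for 4-methoxyphenyl on the sulfonamide nitrogen and so changes two things at once; it does not separate the methyl itself from the rest of that exchange. It shows only that the aryl substituent can shift the number by at least that much. Removing one methyl is a smaller structural change than that swap, so no more than a modest loss is expected for compound 3, a step of a 2.1-fold higher number from compound 2 to compound 3 (0.32 log units; beyond the scatter). Compound 3 is therefore estimated at 400 nM, with a range of 150 nM to 1500 nM.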

Compound 3, half-maximal inhibitory concentration: 470 nM
For compound 3 the middle estimate is 1.2-fold (0.07 log units) below the measured one, and the stated range covers the measured number.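

In this assay the methyl on the aromatic carbon now has a size of its own, apart from the rest of the earlier aryl exchange, and the step is modest: a 2.5-fold higher number from compound 2 to compound 3 (0.39 log units; beyond the scatter). Hydrogen in place of methoxy also moves the number, so the unsubstituted phenyl compound is not the poorest of the three as far as the values go: an at least 2.1-fold lower number from compound 1 to compound 3 (0.32 log units; beyond the scatter). The value of compound 1 is a limit and not a number, so that step gives only a lower bound on its size: the limit of > 1000 nM in this assay, at which 1 of the 3 values shown sits.

Methyl and methoxy are read at different places on the ring, so the effect of the group and the effect of its place cannot be told apart for compound 1. As far as these compounds go, how an ethyl group, an amine or a carboxylic acid at the place of the methyl in compound 2 would read remains open.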